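The compounds below may be only part of what the source reports. "The series", "measured", "known", "first", "only" and "open" are said of these compounds alone.

Measured compounds:

Compound 1, `COc1cc(-c2nn(-c3cccc(NC(=O)Nc4cc(C(F)(F)F)cc(C(F)(F)F)c4)c3)cc2-c2ccncc2)ccc1Cl`, gives 10900 nM in a functional assay on MCF7 cells (Homo sapiens) for inhibition, read by sulforhodamine B assay, with a stated time of 48 h; on this read-out lower numbers stand for stronger inhibition of growth and higher numbers for weaker inhibition of growth.
Compound 2, `O=C(Nc1cccc(-n2cc(-c3ccncc3)c(-c3ccc(Cl)c(O)c3)n2)c1)Nc1cc(C(F)(F)F)cc(C(F)(F)F)c1`, gives 5790 nM in this assay.
Compound 3, `COc1cc(-c2nn(-c3cccc(NC(=O)Nc4ccc(Cl)c(C(F)(F)F)c4)c3)cc2-c2ccncc2)ccc1Cl`, gives only a limit in this assay, > 32500 nM.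

Within the data shown here, the value recorded for compound 3 is a limit of the assay and not a number; it is the one value that sits at the limit of > 32500 nM in this assay, at which 1 of the 3 values shown sits. Compound 1 and compound 2 differ in one place, (hydrogen in place of methyl on an oxygen on an aromatic ring), and the step of a 1.9-fold lower number from compound 1 to compound 2 (0.27 log units; within the scatter). The difference between the core of compound 1 and the core of compound 3 is not broken down here.

Compound 4, `O=C(Nc1cccc(-n2cc(-c3ccncc3)c(-c3ccc(Cl)c(O)c3)n2)c1)Nc1ccc(Cl)c(C(F)(F)F)c1`, has not yet been measured in this assay. It stands to compound 3 as compound 2 stands to compound 1: hydrogen in place of methyl on an oxygen on an aromatic ring, the same change at the same kind of place. Among the measured compounds shown here, on the one measured occasion that change moved the value by a 1.9-fold lower number from compound 1 to compound 2 (0.27 log units; within the scatter), a step within the scatter, so no large movement is expected here either. Starting from a limit for compound 3, the expected step is an at least 1.3-fold lower number from compound 3 to compound 4 (0.11 log units; that floor lies within the scatter), which rests on the step from compound 1 to compound 2. Compound 4 is therefore estimated at 25000 nM, with a range from 10000 nM to 60000 nM, and a real chance remains that compound 4 again returns only a limit.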

Compound 4, concentration for total growth inhibition: > 32500 nM
Compound 4: only a limit was reported; the forecaster's own chance of this, stated with the estimate: 55%; middle value at least 1.3-fold (0.11 log units) from the limit.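

In this assay compound 4 gives > 32500 nM, which is a limit and not a number. Compound 3 likewise gives a limit, > 32500 nM. No step can be read between compound 3 and compound 4, and the two now share the same limit: the limit of > 32500 nM in this assay, at which 2 of the 4 values shown sit.

The compounds shown leave open whether methoxy to hydroxy changes growth inhibition at all when compound 3 and compound 4 are compared.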